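A few compounds are considered here, and "the series" means these few. Any claim that something is new, unique, unknown or untested is made for them only; others in the source may bear on it.

Compound 2 `Cc1ccnc(NC(c2ccccc2F)c2ccc3cccnc3c2O)c1` is one of three related compounds measured in an assay for inhibition of protein disulfide-isomerase (Homo sapiens), with a stated time of 1 h; a higher number here means a weaker inhibitor, a lower number a stronger inhibitor. Compound 1 `Oc1c(C(Nc2ccccn2)c2ccccc2F)ccc2cccnc12` gives 470 nM, compound 3 `COc1ccccc1NC(c1ccccc1)c1ccc2cccnc2c1O` gives 390 nM, and compound 2 gives 880 nM, the highest of the three numbers, within the scatter of compound 1 and beyond it only against compound 3. For the measured compounds named here, the single one-place step among them, a 1.9-fold higher number from compound 1 to compound 2 (0.27 log units; within the scatter), concerns a methyl group and not the fluorophenyl ring.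

Compound 4 `Cc1ccnc(NC(c2cccc(F)c2)c2ccc3cccnc3c2O)c1` has not yet been measured. It differs from compound 2 by 3-fluorophenyl in place of 2-fluorophenyl on a saturated chain carbon bound to an aromatic carbon and a nitrogen on an aromatic ring. Going by the values given here, no measured step touches the fluorophenyl ring: compound 3 carries a plain phenyl ring but also differs elsewhere, so its value beside that of compound 2 says nothing clean about the fluorine alone. With nothing to point either way, the expectation for compound 4 in this assay is a step of no change at the digits printed from compound 2 to compound 4 (within the scatter) that stays within the scatter. Compound 4 is therefore estimated at 880 nM, with a range from 400 nM to 2000 nM.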

Compound 4, half-maximal inhibitory concentration: 350 nM
Estimate against measurement, compound 4: 2.5-fold (0.40 log units) above; the whole stated range lies above it.
By their numbers in this assay, from the lowest: compounds 4, 3, 1 and 2 (each within the scatter of the next, the first and the last beyond it).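

For the compounds shown here, changing 3-fluorophenyl for 2-fluorophenyl is the first change at this saturated chain carbon that can be read on its own, and in this assay it gives a 2.5-fold lower number from compound 2 to compound 4 (0.40 log units; beyond the scatter), a modest step but one beyond the scatter. The two compounds hold the same atoms, joined differently, so the fluorine's place on the phenyl ring alone is enough to shift the number, which the earlier step, concerning only the methyl group, could not show. Nothing available explains this shift.

As far as these compounds go, it remains open whether the same change would carry over to the core of compound 1, which lacks the methyl group. Also open, from the compounds shown here alone, is how a chlorine atom, a methoxy group or a nitrile in place of the fluorine would compare on this ring.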